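This account rests on a few compounds, and the source may have more. Where it says the series, first, only, none or still open, it means among the compounds named here.

Measured compounds:
Compound 1 `CCCN(CCC)c1nc(C(C)(C)C)ccc1CNC(=O)C(C)c1ccc(NS(C)(=O)=O)c(F)c1` gives 2.5 nM in an assay on cells for antagonist activity at transient receptor potential cation channel subfamily V member 1 (Homo sapiens), read by FLIPR and calcium flux, with a stated time of 6 min; a higher number here means a weaker inhibitor, a lower number a stronger inhibitor.
Compound 2 `CCCCCSc1nc(C(C)(C)C)ccc1CNC(=O)C(C)c1ccc(NS(C)(=O)=O)c(F)c1` gives 3.1 nM in this assay.

Compound 2 stands at the higher of the two numbers, but its gap to compound 1 is small: a 1.2-fold higher number from compound 1 to compound 2 (0.09 log units; within the scatter). On the numbers shown, the two compounds cannot be told apart.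

Compound 3 `CC(C(=O)NCc1ccc(C(C)(C)C)nc1SCCCN(C)C)c1ccc(NS(C)(=O)=O)c(F)c1` is not yet measured. It differs from compound 2 in one place: dimethylamino in place of ethyl on a saturated chain carbon, three bonds along the chain from a sulfur. The chain that hangs from the sulfur keeps its length, and only its far end is exchanged.

Among the measured compounds shown here, the one measured step, from compound 1 to compound 2, swapped the whole group on the aromatic carbon and barely moved the number. That step does not touch the end of the chain, so it gives no direct guide to the present change; it shows only that this part of the molecule has tolerated a large exchange once. Without a closer precedent, a modest step is expected in this assay, most likely toward a somewhat higher number, though a result within the scatter would not be surprising.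

Compound 3 is therefore estimated at 8 nM, with a range from 2 nM to 40 nM, corresponding to an expected step of a 2.6-fold higher number from compound 2 to compound 3 (0.41 log units; beyond the scatter).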

Compound 3, inhibition constant: 51.8 nM
Compound 3: the middle estimate sits 6.5-fold (0.81 log units) below what was measured, outside the stated range (above it).
By their numbers in this assay, from the lowest: compounds 1 and 2 (each within the scatter of the next); then compound 3.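

In this assay the far end of the chain on the sulfur proves to matter: dimethylamino in place of ethyl, on a saturated chain carbon three bonds along the chain from the sulfur, gives a 17-fold higher number from compound 2 to compound 3 (1.22 log units; beyond the scatter) even though the chain keeps its length. Set against compound 1, (3-(dimethylamino)propyl)sulfanyl in place of dipropylamino gives a 21-fold higher number from compound 1 to compound 3 (1.32 log units; beyond the scatter) and thus a very different outcome from the earlier exchange, where pentylsulfanyl in place of dipropylamino gave a 1.2-fold higher number from compound 1 to compound 2 (0.09 log units; within the scatter) and stayed within the scatter, so a large exchange here is not always harmless. No measurement at hand says why the number rises so far.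

One compound cannot show whether this rise belongs to dimethylamino alone or would follow any group that replaces the plain carbon end of the chain. A hydroxyl, a methoxy or a carboxylic acid at the same place, or a longer chain carrying dimethylamino, would begin to separate these possibilities.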